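The compounds below may be only part of what the source reports. "The series", "measured", "known", "first", "only" and "open" are said of these compounds alone.

Compound 1, `O=C(CSc1nc(Nc2ccccc2)c2ccccc2n1)Nc1ccccc1Br`, gives 18600 nM in a functional assay on MGC-803 cells (Homo sapiens) for inhibition, read by MTT assay, with a stated time of 72 h; on this read-out higher numbers stand for weaker inhibition and lower numbers for stronger inhibition.
Compound 2, `O=C(CSc1nc(Nc2ccccc2)c2ccccc2n1)Nc1ccc([N+](=O)[O-])cc1`, reaches only the limit of this assay, > 50000 nM.
Compound 3, `C=CC(=O)Nc1cccc(NC(=O)CSc2nc(Nc3ccccc3F)c3ccccc3n2)c1`, gives 26100 nM in this assay.

Among the two numbers that are not limits, compound 3 and compound 1 lie within the scatter of each other, so neither can be set above the other. Compound 2 sits at the limit of > 50000 nM in this assay, at which 1 of the 3 values shown sits, and gives no number at all.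

Compound 4 is `C=CC(=O)Nc1cccc(NC(=O)CSc2nc(Nc3cccc(Br)c3)c3ccccc3n2)c1`. It differs from compound 3 in one place: 3-bromophenyl in place of 2-fluorophenyl on a nitrogen on an aromatic ring.

Among the measured compounds shown here, only one measured step exists, an at least 2.6-fold higher number from compound 1 to compound 2 (0.42 log units; beyond the scatter), and it concerns the amide-type nitrogen, a different place from the one changed here; it also runs into the limit (the limit of > 50000 nM in this assay, at which 1 of the 3 values shown sits), so its full size is unknown. For the measured compounds named here, no measured step touches the nitrogen on the aromatic ring, and no measured pair shows a halogen moved from one position of a phenyl ring to another at that place.

With nothing to point the other way, compound 4 is expected to stay close to compound 3, a step of a 1.0-fold lower number from compound 3 to compound 4 (0.02 log units; within the scatter) that lies within the scatter. Compound 4 is therefore estimated at 25000 nM, with a range from 9000 nM to 60000 nM.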

Compound 4, half-maximal inhibitory concentration: 11900 nM
The estimate for compound 4 lay 2.1-fold (0.32 log units) above the measured number; the range from low to high includes it.
By their numbers in this assay, from the lowest: compounds 4, 1 and 3 (each within the scatter of the next, the first and the last beyond it). At a limit, above all of these: compound 2.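

In this assay, among the compounds shown here, replacing 2-fluorophenyl with 3-bromophenyl on the nitrogen on an aromatic ring gives a 2.2-fold lower number from compound 3 to compound 4 (0.34 log units; beyond the scatter), the first measured step at this place, and it shows that the read-out responds to a change here, though only modestly. The halogen and its position on the phenyl ring change together in this single step, so the step belongs to the two changes jointly and cannot be divided between them. Nothing measured in this set gives a reason for the step.

The compounds shown leave open whether the gain follows the bromine or the position, a question that 3-fluorophenyl and 2-bromophenyl at this same nitrogen would separate, and how an unsubstituted phenyl would compare with both. For the compounds shown here, they also leave open how this place would respond to something other than a halogen on the phenyl ring, such as an amine, a carboxylic acid or a longer chain, since only two groups have been compared here and a single step cannot establish a trend.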